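Estimating Compound 4 from Three Measured Analogues

The source may report more compounds than this note shows. Statements on the series, on what has been measured and on what is new or still open speak of the compounds shown alone.

Measured in a functional assay on B16-F10 cells (Mus musculus) for antiproliferative activity, read by MTT assay, with a stated time of 48 h; a higher number here means a weaker inhibitor, a lower number a stronger inhibitor:
compound 1, `COc1ccc(/C=C/c2cc(OC)cc(OC)c2/C=C/C(=O)c2ccc(Cl)c(Cl)c2)cc1`, compound 1 gives 7.5 ug/mL
compound 2, `COc1ccc(/C=C/c2cc(OC)cc(OC)c2/C=C/C(=O)c2cccc(Br)c2)cc1`, compound 2 gives 5.1 ug/mL
compound 3, `COc1ccc(/C=C/c2cc(OC)cc(OC)c2/C=C/C(=O)c2ccccc2)cc1`, compound 3 gives 3.7 ug/mL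

Compound 1 has the highest number of the three. Its nearest neighbour is compound 2, with a 1.5-fold lower number from compound 1 to compound 2 (0.17 log units; within the scatter); the furthest is compound 3, with a 2.0-fold lower number from compound 1 to compound 3 (0.31 log units; beyond the scatter). Between those two, a 1.4-fold lower number from compound 2 to compound 3 (0.14 log units; within the scatter). Taken together, the three values show that the unsubstituted phenyl ring on the carbonyl carbon gives a modestly lower number than the 3,4-dichlorophenyl ring, while the 3-bromophenyl ring sits in between and within the scatter of both.

Compound 4, `CCN(CC)c1ccc(C(=O)/C=C/c2c(/C=C/c3ccc(OC)cc3)cc(OC)cc2OC)cc1`, is still to be measured in this assay. It differs from compound 1 as follows: 4-(diethylamino)phenyl in place of 3,4-dichlorophenyl on a carbonyl carbon. Going by the values given here, no measured step involves a 4-(diethylamino)phenyl group, so only the steps away from the 3,4-dichlorophenyl ring, a 1.5-fold lower number from compound 1 to compound 2 (0.17 log units; within the scatter) and a 2.0-fold lower number from compound 1 to compound 3 (0.31 log units; beyond the scatter), bear on the question, and both lower the number. The step for compound 4 is therefore expected to be of similar or slightly larger size in the same direction, roughly a 1.7-fold lower number from compound 1 to compound 4 (0.22 log units; within the scatter). Compound 4 is accordingly estimated at 4.5 ug/mL, with a plausible range from 1.5 ug/mL to 13 ug/mL.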

Compound 4, half-maximal inhibitory concentration: 8.1 ug/mL
Compound 4: the middle estimate sits 1.8-fold (0.26 log units) below what was measured; the measured number falls inside the stated range.
By their numbers in this assay, from the lowest: compounds 3, 2, 1 and 4 (each within the scatter of the next, the first and the last beyond it).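

In this assay, a ring carrying an amine at this carbonyl carbon reads no differently from the halogen-bearing rings, as 4-(diethylamino)phenyl in place of 3,4-dichlorophenyl gives a 1.1-fold higher number from compound 1 to compound 4 (0.03 log units; within the scatter), and in place of 3-bromophenyl it gives a 1.6-fold higher number from compound 2 to compound 4 (0.20 log units; within the scatter). Going by these compounds alone, the one new step that clears the scatter is diethylamino in place of hydrogen on an aromatic carbon, with a 2.2-fold higher number from compound 3 to compound 4 (0.34 log units; beyond the scatter), so compound 1 and compound 4 both stand beyond the scatter from the unsubstituted phenyl ring of compound 3 although their rings share no substituent, while compound 2 goes against this pattern by staying within the scatter of compound 3. No measurement among those given explains this result.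

The compounds shown do not tell whether a smaller amine such as dimethylamino, or a morpholine ring, at this carbonyl-bound phenyl ring would read like compound 4 or like compound 3. They also leave open what a hydroxyl group or a carboxylic acid on that ring would do to the number.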